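Moving a chlorine atom: what compound 4 should give

The source may report more compounds than this note shows. Statements on the series, on what has been measured and on what is new or still open speak of the compounds shown alone.

In a functional assay on MCF7 cells (Homo sapiens) for inhibition, read by MTT assay, with a stated time of 48 h (a lower number here means a stronger inhibitor, a higher number a weaker inhibitor), compound 1 `O=C(N/N=C/c1c(-c2cc3ccccc3oc2=O)[nH]c2ccccc12)c1ccc(Cl)cc1` reaches only the limit > 200000 nM, so no number is known for it (the limit of > 200000 nM in this assay, at which 1 of the 3 values shown sits). Compound 2 `O=C(N/N=C/c1c(-c2cc3ccccc3oc2=O)[nH]c2ccccc12)c1ccccc1Cl` gives 164000 nM. The change between them is 2-chlorophenyl in place of 4-chlorophenyl on a carbonyl carbon, and it made a step of an at least 1.2-fold lower number from compound 1 to compound 2 (0.08 log units; that floor lies within the scatter). Compound 3 `O=C(N/N=C/c1c(-c2cc3ccc(Br)cc3oc2=O)[nH]c2ccccc12)c1ccc(Cl)cc1` gives 13800 nM; its core differs from the core of compound 1 by bromo in place of hydrogen on an aromatic carbon, a step of an at least 14-fold lower number from compound 1 to compound 3 (1.16 log units; beyond the scatter). Compound 4 `O=C(N/N=C/c1c(-c2cc3ccc(Br)cc3oc2=O)[nH]c2ccccc12)c1ccccc1Cl` has not yet been measured. It differs from compound 3 by 2-chlorophenyl in place of 4-chlorophenyl on a carbonyl carbon, the same change that turned compound 1 into compound 2, at a place described in exactly the same words, so it is the same change. The step is expected to be a 1.3-fold lower number from compound 3 to compound 4 (0.10 log units; within the scatter), resting on the small step of an at least 1.2-fold lower number from compound 1 to compound 2 (0.08 log units; that floor lies within the scatter). Compound 4 is therefore estimated at 11000 nM, expected between 3500 nM and 40000 nM.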

Compound 4, half-maximal inhibitory concentration: > 192000 nM
Compound 4: a limit, no number (the forecaster's own chance of this, stated with the estimate: 5%); at least 17-fold (1.24 log units) between middle value and limit.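

In this assay compound 4 reaches only a limit, > 192000 nM, so the steps ending at it give minimum sizes, not exact ones. Moving the chlorine does not carry over from one core to the other, as the bromo core shows a large step of an at least 13-fold higher number from compound 3 to compound 4 (1.14 log units; beyond the scatter), set against a very different result on the core without bromo: the same change on two cores in this assay, an at least 1.2-fold lower number (0.08 log units; that floor lies within the scatter) from compound 1 to compound 2 and an at least 13-fold higher number (1.14 log units; beyond the scatter) from compound 3 to compound 4, at least 16-fold (1.22 log units) apart, beyond the scatter of two such steps The bromo change does not carry over either, with a step of only an at least 1.1-fold higher number from compound 2 to compound 4 (0.06 log units; that floor lies within the scatter), although the exact size of these steps and the reason for the gap remain unknown: the same change on two cores in this assay, an at least 14-fold lower number (1.16 log units; beyond the scatter) from compound 1 to compound 3 and an at least 1.1-fold higher number (0.06 log units; that floor lies within the scatter) from compound 2 to compound 4, at least 16-fold (1.22 log units) apart, beyond the scatter of two such steps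

Going by these compounds, it remains open whether this dependence on the core also holds for other replacements. A methoxy group or an amine in place of the chlorine, or a chloro group in place of the bromo, could test this.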